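The compounds below may be only part of what the source reports. "The series", "measured", "known", "first", "only" and "open" are said of these compounds alone.

Compound 1 `Cn1cc(-c2cnc3ccc(NCc4ccc(F)cc4)nc3c2)cn1` and compound 3 `Cn1cc(-c2cnc3ccnc(NCc4ccc(F)cc4)c3c2)cn1` share the same atoms joined differently; the difference between their two cores is not broken down here. In a functional assay on A549 cells (Homo sapiens) for antiproliferative activity, read by MTT assay, with a stated time of 48 h (a lower number here means a stronger inhibitor, a higher number a weaker inhibitor), compound 1 gives only a limit, > 50000 nM. Compound 2 `COc1ccc(CNc2ccc3ncc(-c4cnn(C)c4)cc3n2)cc1` likewise gives a limit in this assay, > 50000 nM. Going by the values given here, compound 3 is the one member with a number in this assay, 5200 nM. From compound 1 to compound 2 the change is methoxy in place of fluoro on an aromatic carbon, and its step, a step that the two limits leave unreadable from compound 1 to compound 2, cannot be read because of the limit of > 50000 nM in this assay, at which 2 of the 3 values shown sit. Compound 4 `COc1ccc(CNc2nccc3ncc(-c4cnn(C)c4)cc23)cc1` carries the same change on the core of compound 3: methoxy in place of fluoro on an aromatic carbon. With no readable size from the measured pair, compound 4 is expected to stay close to its parent, the expected step being a 1.2-fold higher number from compound 3 to compound 4 (0.06 log units; within the scatter). Compound 4 is therefore estimated at 6000 nM, between 2000 nM and 20000 nM.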

Compound 4, half-maximal inhibitory concentration: > 50000 nM
Compound 4: only a limit was reported; the forecaster's own chance of this, stated with the estimate: 15%; middle value at least 8.3-fold (0.92 log units) from the limit.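

In this assay, methoxy in place of fluoro on the core of compound 3 gives an at least 9.6-fold higher number from compound 3 to compound 4 (0.98 log units; beyond the scatter), so on this core the change weakens the compound beyond the scatter. On these data alone, compound 4 gives only a limit, > 50000 nM, so the true size of the step stays unknown. The step from compound 1 to compound 2 cannot be read, so the pair on the other core neither confirms nor contradicts this result, and whether the change behaves alike on both cores remains unshown, for this reason: the limit of > 50000 nM in this assay, at which 3 of the 4 values shown sit.

The compounds shown leave open whether the drop is specific to methoxy, since only 4-fluorophenyl and 4-methoxyphenyl are compared. As far as these compounds go, how a nitrile, a hydroxyl or an amine in place of the fluoro would read in this assay also remains open.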